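Swapping the aryl ketone substituent: expected cytotoxicity of compound 4

A few compounds are considered here, and "the series" means these few. Any claim that something is new, unique, unknown or untested is made for them only; others in the source may bear on it.

Compound 1 `COC(=O)c1cc(-c2cccc(NC(=O)c3ccc(/C=C/C(=O)c4ccc(F)cc4)cc3)c2)on1`, a limit: > 20 ug/mL
Compound 2 `COC(=O)c1cc(-c2cccc(NC(=O)c3ccc(/C=C/C(=O)c4ccc(C)cc4)cc3)c2)on1`, a limit: > 80 ug/mL
Compound 3 `COC(=O)c1cc(-c2cccc(NC(=O)c3ccc(/C=C/C(=O)c4ccc(C)c(F)c4)cc3)c2)on1`, a limit: > 50 ug/mL

In an ADME assay on Vero cells (Chlorocebus sabaeus) for cytotoxicity, read by MTT assay, with a stated time of 72 h (on this read-out lower numbers stand for higher toxicity in this test and higher numbers for lower toxicity in this test), compound 3 gives only a limit of the assay, not a number. The other two values are also limits, so no ordering can be read among the three. Compound 4 `COC(=O)c1cc(-c2cccc(NC(=O)c3ccc(/C=C/C(=O)c4ccc(Cl)cc4)cc3)c2)on1` differs from compound 3 by 4-chlorophenyl in place of 3-fluoro-4-methylphenyl on a carbonyl carbon. For the measured compounds named here, the steps that bear on this change are both unreadable: a step that the two limits leave unreadable from compound 1 to compound 3 and a step that the two limits leave unreadable from compound 2 to compound 3, and likewise a step that the two limits leave unreadable from compound 1 to compound 2. With only limits at hand, no step beyond the scatter can be expected in this assay, and compound 4 is estimated to be reported as a limit as well, giving a step that the limit leaves unreadable from compound 3 to compound 4. The expected value for compound 4 is 60 ug/mL, within 20 ug/mL to 150 ug/mL.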

Compound 4, half-maximal cytotoxic concentration: > 50 ug/mL
Compound 4 gave a limit, no number (the forecaster's own chance of this, stated with the estimate: 80%); the middle value does not contradict the limit.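

For the compounds shown here, compound 4 gives only a limit, as do compound 1, compound 2 and compound 3; no step among them can be read in this assay. Going by these compounds, whether any of these aryl ketone swaps changes cytotoxicity remains open.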